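The source may hold more compounds than are shown below. What is called first, only, known or untested is meant among the compounds shown, and "the series" means these compounds.

In a functional assay on Caco-2 cells (Homo sapiens) for antiproliferative activity, with a stated time of 48 h (on this read-out higher numbers stand for weaker inhibition and lower numbers for stronger inhibition), compound 1 `CCN(CC)c1ccc(-c2ccc(C(=O)OC)cc2)nn1` gives 250 nM. Compound 2 `CCOC(=O)c1ccc(-c2ccc(N(C)C)nn2)cc1` reads > 25000 nM, which is a limit and not a number. Compound 2 thus stands at the limit of > 25000 nM in this assay, at which 1 of the 2 values shown sits. Compound 3 `COC(=O)c1ccc(-c2ccc(N(C)C)nn2)cc1` replaces the ethoxycarbonyl of compound 2 with methoxycarbonyl: hydrogen in place of methyl on a saturated chain carbon bound to an oxygen next to a carbonyl group. Compound 1 also carries methoxycarbonyl and gives 250 nM, so a step toward stronger inhibition in this assay is expected, though its size is uncertain. The estimated step is an at least 6.2-fold lower number from compound 2 to compound 3 (0.79 log units; beyond the scatter). For compound 3 the estimated value is 4000 nM, with an expected range of 400 nM to 25000 nM.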

Compound 3, half-maximal inhibitory concentration: > 25000 nM
Compound 3 was reported as a limit; the forecaster's own chance of this, stated with the estimate: 30%; at least 6.2-fold (0.79 log units) between middle value and limit.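

In this assay, the change from ethoxycarbonyl to methoxycarbonyl cannot be read, as compound 2 and compound 3 are both reported only as limits. With methoxycarbonyl held fixed, the change to dimethylamino in place of diethylamino on an aromatic carbon gives an at least 100-fold higher number from compound 1 to compound 3 (2.00 log units; beyond the scatter), so methoxycarbonyl alone does not keep the measured activity of compound 1. Both dimethylamino compounds, compound 2 and compound 3, now sit at the same limit: the limit of > 25000 nM in this assay, at which 2 of the 3 values shown sit.

Going by these compounds, it remains open whether diethylamino paired with ethoxycarbonyl would read like compound 1. Also open, on these data alone, is how a longer chain on the amine, such as dipropylamino, a pyrrolidine, or a carboxylic acid in place of the ester would read.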